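The source may hold more compounds than are shown below. What is called first, only, known or untested is meant among the compounds shown, and "the series" means these compounds.

Measured in a functional assay on A549 cells (Homo sapiens) for antiproliferative activity, read by MTT assay, with a stated time of 72 h; a higher number here means a weaker inhibitor, a lower number a stronger inhibitor:
- compound 1 `NC1=NC2(CCSCC2)N(OCCCOc2cccc(Cl)c2)C(N)=N1`: 60 nM
- compound 2 `NC1=NC2(CCOCC2)N(OCCCOc2cc(Cl)c(Cl)cc2Cl)C(N)=N1`: 680 nM

Of these two, compound 1 has the lower number and so is the stronger inhibitor. The number for compound 2 is clearly higher, and the gap lies beyond the usual scatter of repeated measurements. Compound 2 also differs from compound 1 in more than one place, so this gap says little about any single change.

Compound 3 `NC1=NC2(CCSCC2)N(OCCCOc2ccccc2Cl)C(N)=N1` has not been measured yet. It carries 2-chlorophenyl in place of 3-chlorophenyl on an oxygen on a saturated carbon. The atoms are the same, only joined differently.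

Within the data shown here, no measured pair shows a change of this kind, so any expectation is loose. Among the measured compounds shown here, compound 1, at 60 nM, holds the lower of only two numbers, which tilts the expectation towards a higher number for a close relative. In this assay, a modest rise is expected, a 2.0-fold higher number from compound 1 to compound 3 (0.30 log units; within the scatter), and it may stay within the scatter. Compound 3 is estimated at 120 nM, with an expected range from 30 nM to 500 nM.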

Compound 3, half-maximal inhibitory concentration: 80 nM
Estimate against measurement, compound 3: 1.5-fold (0.18 log units) above; low and high end bracket the measured number.
By their numbers in this assay, from the lowest: compounds 1 and 3 (each within the scatter of the next); then compound 2.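

In this assay, among these compounds, the step from the 3-chlorophenyl to the 2-chlorophenyl group is a 1.3-fold higher number from compound 1 to compound 3 (0.12 log units; within the scatter) and gives the first reading of a single change in these compounds. On this evidence the two placements of the one chlorine cannot be told apart at this end of the molecule, at least when the rest of compound 1 stays as it is. No measured property of these compounds bears on this result, so the likeness of the two numbers stands without an explanation.

The compounds shown do not say whether the same tolerance would hold for a different group on the phenyl ring, such as a fluorine, a methoxy group or a nitrile, for a bare phenyl, or for a shorter or longer chain between the two oxygens. Compound 2 differs from both of these compounds in more than one place, so its value cannot yet be tied to its extra chlorines, to the change in the core, or to any other single feature.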